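The source may report more compounds than this note shows. Statements on the series, on what has been measured and on what is new or still open speak of the compounds shown alone.

Measured in a functional assay on LNCaP cells (Homo sapiens) for cytotoxicity, read by MTT assay, with a stated time of 72 h; on this read-out lower numbers stand for stronger inhibition and higher numbers for weaker inhibition:
compound 1 `c1ccc2nc3c(cc2c1)Cn1c-3nc2ccccc21` gives 11300 nM;
compound 2 `Brc1cccc2cc3c(nc12)-c1nc2ccccc2n1C3` gives 8400 nM;
compound 3 `Cc1ccc2nc3c(cc2c1)Cn1c-3nc2ccccc21` gives 62500 nM.

Compound 3 carries the highest number of the three. Relative to compound 1 the step is a 5.5-fold higher number from compound 1 to compound 3 (0.74 log units; beyond the scatter), while in the other direction a 1.3-fold lower number from compound 1 to compound 2 (0.13 log units; within the scatter). Compound 4 `COc1ccc2nc3c(cc2c1)Cn1c-3nc2ccccc21` differs from compound 3 by methoxy in place of methyl on an aromatic carbon. For the measured compounds named here, no measured step exchanges methyl for methoxy, so the only guide is that adding methyl to compound 1 raised the number in this assay, whereas adding bromo did not move it beyond the scatter. The estimated step is therefore a 2.1-fold lower number from compound 3 to compound 4 (0.32 log units; beyond the scatter), a partial return toward compound 1, with wide uncertainty. Compound 4 is expected to give about 30000 nM, within a range of 8000 nM to 110000 nM.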

Compound 4, half-maximal inhibitory concentration: 24700 nM
For compound 4 the middle estimate is 1.2-fold (0.08 log units) above the measured one; the measured number falls inside the stated range.
By their numbers in this assay, from the lowest: compounds 2 and 1 (each within the scatter of the next); then compound 4; then compound 3.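

Read in this assay, the exchange of methyl for methoxy gives a 2.5-fold lower number from compound 3 to compound 4 (0.40 log units; beyond the scatter) on the same aromatic carbon, so the number at this position depends on which group sits there, not only on the hydrogen being replaced. Against hydrogen, methoxy still gives a 2.2-fold higher number from compound 1 to compound 4 (0.34 log units; beyond the scatter) and so, like methyl, leaves a higher number than the core of compound 1. Nothing measured here accounts for this order. Going by these compounds, whether an amine or a carboxylic acid on this carbon would bring the number below that of compound 1 stays open.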